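This account rests on a few compounds, and the source may have more. Where it says the series, first, only, none or still open, it means among the compounds named here.

Two compounds share one core and differ only in the group on the ring nitrogen. In an in vitro functional assay on HEK293-A cells for negative allosteric modulation of metabotropic glutamate receptor 5 (Homo sapiens), read by FLIPR and calcium flux (a lower number here means a stronger inhibitor, a higher number a weaker inhibitor), compound 1 `O=C1CC(c2nc(-c3cccc(Cl)c3)no2)CN1Cc1ccc(F)cc1` gives 3600 nM, while compound 2 `CC(C)CN1CC(c2nc(-c3cccc(Cl)c3)no2)CC1=O` gives 920 nM, a change of a 3.9-fold lower number from compound 1 to compound 2 (0.59 log units; beyond the scatter). Compound 2 therefore holds the lower of the two numbers. Compound 3 `Cc1ccc(N2CC(c3nc(-c4cccc(Cl)c4)no3)CC2=O)cc1` carries 4-methylphenyl in place of isobutyl on an amide-type nitrogen in a ring. For the measured compounds named here, the single measured step swapped one nitrogen substituent for another, and its size offers the only guide, though an aromatic ring bound straight to the nitrogen is new here. For compound 3 a step of a 1.6-fold higher number from compound 2 to compound 3 (0.21 log units; within the scatter) in this assay is expected, giving an estimated 1500 nM within a range from 400 nM to 6000 nM.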

Compound 3, half-maximal inhibitory concentration: > 10000 nM
Compound 3: only a limit was reported; the forecaster's own chance of this, stated with the estimate: 5%; middle value at least 6.6-fold (0.82 log units) away from the limit.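

For compound 3 only a limit was reported, not a number: the limit of > 10000 nM in this assay, at which 1 of the 3 values shown sits. Placing 4-methylphenyl directly on the ring nitrogen gives an at least 10-fold higher number from compound 2 to compound 3 (1.03 log units; beyond the scatter), and an at least 2.7-fold higher number from compound 1 to compound 3 (0.44 log units; beyond the scatter). This position therefore does not treat all carbon-only groups alike, and compound 3 is the weakest of the three.

The compounds shown cannot separate the effect of the aromatic ring sitting directly on the nitrogen from that of its methyl group. From the compounds shown here alone, a plain phenyl, a longer chain or a chain ending in an amine remains untested here.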